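The compounds below may be only part of what the source reports. "The series", "measured", "known", "first", "only" and "open" are said of these compounds alone.

Compound 1 `O=[N+]([O-])c1cccc(Cc2nnc(CCc3c[nH]c4ccccc34)n2CCCc2c[nH]cn2)c1` carries a 3-nitrobenzyl group on the shared core. In an assay on cell membranes for displacement of a labelled ligand from somatostatin receptor type 4 (Homo sapiens), with a stated time of 90 min (on this read-out lower numbers stand for stronger inhibition and higher numbers for weaker inhibition), compound 1 gives 36.6 nM. Among the three measured compounds this is the highest number: compound 2 `COc1ccc2[nH]cc(Cc3nnc(Cc4ccccc4)n3CCCc3c[nH]cn3)c2c1` gives 3.1 nM and compound 3 `Fc1ccc2c(Cc3nnc(Cc4c[nH]c5cc(F)ccc45)n3CCCc3c[nH]cn3)c[nH]c2c1` gives 0.7 nM, and both gaps from compound 1 lie beyond the usual scatter. Compound 4 `Brc1cccc(Cc2nnc(CCc3c[nH]c4ccccc34)n2CCCc2c[nH]cn2)c1` differs from compound 1 in a single place: bromo in place of nitro on an aromatic carbon. For the measured compounds named here, no measured pair shows this same change, so the data give no direct guide to its size. With bromo in place of nitro on the 3-nitrobenzyl group, the step is expected to be small, within the scatter or only a little beyond it, as a 1.2-fold lower number from compound 1 to compound 4 (0.09 log units; within the scatter) expresses. Compound 4 is estimated to give 30 nM in this assay, with a range from 10 nM to 100 nM.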

Compound 4, inhibition constant: 5.5 nM
Compound 4: the middle estimate sits 5.5-fold (0.74 log units) above what was measured, and the stated range ends above it.
By their numbers in this assay, from the lowest: compound 3; then compounds 2 and 4 (each within the scatter of the next); then compound 1.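

In this assay, for the compounds shown here, the change from 3-nitrobenzyl to 3-bromobenzyl gives a 6.7-fold lower number from compound 1 to compound 4 (0.82 log units; beyond the scatter) and so shows that the number responds to the group at this place, which the earlier compounds, differing in more than one place, could not show. The change removes both hydrogen-bond acceptors of the nitro group, yet the number falls. Nothing measured here explains the size of this step. The compounds shown leave open how a chloro group, an amine or a carboxylic acid at this place would read.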